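3-Bromophenyl to 4-bromophenyl: working notes

The source may report more compounds than this note shows. Statements on the series, on what has been measured and on what is new or still open speak of the compounds shown alone.

- compound 1 `COC(=O)C1=C(C)N=C(C)/C(=C(\O)OC)C1c1cccc(O)c1`: 1000 nM
- compound 2 `COC(=O)C1=C(C)N=C(C)/C(=C(\O)OC)C1c1cccc(Br)c1`: 1.29 nM

Both values come from a functional assay (muscle tissue) with Cavia porcellus as the target; a higher number here means that more compound is needed for the effect, a lower number that less compound is needed. Of the two numbers, compound 2 holds the lower, 1.29 nM. The next structure is compound 3 `COC(=O)C1=C(C)N=C(C)/C(=C(\O)OC)C1c1ccc(Br)cc1`, which has the same atoms as compound 2, joined differently: 4-bromophenyl in place of 3-bromophenyl on a saturated ring carbon. Among the compounds with values here, only one measured step bears on this change: a 780-fold lower number from compound 1 to compound 2 (2.89 log units; beyond the scatter). That step is large and beyond the scatter, so the group on the phenyl can matter greatly in this series. Within the data shown here, it replaces one group with another, however, and no measured pair shows the effect of moving a group. Among the measured compounds shown here, no measured compound carries the 4-bromophenyl group. A clear rise is therefore expected in this assay, probably smaller than the measured step, and the estimate is a 47-fold higher number from compound 2 to compound 3 (1.67 log units; beyond the scatter). For compound 3 the estimated value is 60 nM, with an expected range from 8 nM to 450 nM.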

Compound 3, half-maximal effective concentration: 540 nM
Compound 3: middle estimate off by 9.0-fold (0.95 log units), on the low side; the measured number lies above the stated range.
By their numbers in this assay, from the lowest: compound 2; then compounds 3 and 1 (each within the scatter of the next).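

In this assay, the move of the bromine alone gives a 420-fold higher number from compound 2 to compound 3 (2.62 log units; beyond the scatter), so with no atom gained or lost, the arrangement on the phenyl ring can decide the number in this series. The low number of compound 2 therefore does not follow from bromine as such: a 1.9-fold lower number from compound 1 to compound 3 (0.27 log units; within the scatter), which leaves 4-bromophenyl and 3-hydroxyphenyl indistinguishable in this assay. Nothing on hand gives a reason for the effect of this move.

On these data alone, it remains open whether a chlorine or an amine in place of the bromine of the 3-bromophenyl group would keep the low number of compound 2. Also open, as far as these compounds go, is whether a hydroxy group responds to the same move as the bromine does.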